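Swapping a Hydroxyalkyl Arm for a Methoxybenzyl Group

This account rests on a few compounds, and the source may have more. Where it says the series, first, only, none or still open, it means among the compounds named here.

Measured so far:
compound 1, `OCCCNCc1nc2c(OCC3CCCCC3)cccc2[nH]1`, 52.7%
compound 2, `CCC(CO)NCc1nc2c(OCC3CCCCC3)cccc2[nH]1`, 94.3%
compound 3, `OCC(CC1CCCCC1)NCc1nc2c(OCC3CCCCC3)cccc2[nH]1`, 94.7%

These three share one core and differ only in the group on the amine nitrogen. In an assay on cells for inhibition of interleukin-5 receptor subunit alpha (Mus musculus), read by WST assay, with a stated time of 48 h, tested at 30 uM, in the presence of a further agent that is not named here (a higher number here means more inhibition at the concentration tested (going by the name of the read-out), a lower number less inhibition), compound 2 stands second highest of the three, with compound 3 so close that the two cannot be told apart, while compound 1 sits far lower: a number 41.6 percentage points higher from compound 1 to compound 2 (beyond the scatter) and a number 0.4 percentage points higher from compound 2 to compound 3 (within the scatter).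

Compound 4, `COc1ccc(CNCc2nc3c(OCC4CCCCC4)cccc3[nH]2)cc1`, has not yet been measured. Its change is 4-methoxybenzyl in place of 1-(hydroxymethyl)propyl on an amine nitrogen. Neither measured step tests this change directly: the step from compound 1 to compound 2 shows that the group on this nitrogen can shift the read-out greatly, and the step from compound 2 to compound 3 shows that a large added group need not change it. For the measured compounds named here, with no close precedent, compound 4 is expected to give 72%, within 40% to 96%, a step of a number 22.3 percentage points lower from compound 2 to compound 4 (beyond the scatter) that is uncertain in size and direction.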

Compound 4, a percentage reported as inhibition, at one concentration (the size of the read-out at that concentration, not a potency): 43.3%
Compound 4: middle estimate off by 28.7 percentage points, on the high side, within the range that was stated.
By their numbers in this assay, from the lowest: compounds 4 and 1 (each within the scatter of the next); then compounds 2 and 3 (each within the scatter of the next).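

In this assay, there is a number 51 percentage points lower from compound 2 to compound 4 (beyond the scatter) when the 4-methoxybenzyl group replaces 1-(hydroxymethyl)propyl, so a six-membered aromatic ring on this amine nitrogen can go with a far lower number than a branched hydroxyalkyl arm. The read-out does not separate this group from the unbranched arm of compound 1, with a number 9.4 percentage points lower from compound 1 to compound 4 (within the scatter) despite their different structures. Nothing measured here explains either step. Open, on these data alone, is whether the methoxy group or the aromatic ring matters more, which a plain benzyl or 4-hydroxybenzyl group could help to show.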